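Methyl on the piperidine ring: compound 3 to compound 4

The compounds below may be only part of what the source reports. "The series", "measured", "known", "first", "only" and "open" are said of these compounds alone.

The series keeps one shared core and varies the amine end of the three-carbon chain and the anilide: compound 1 `COc1cc2c(Nc3nc4ccc(C(=O)Nc5c(C)cccc5Cl)cc4s3)ncnc2cc1OCCCN1CCCCC1C`, compound 2 `CCN(CC)CCCOc1cc2ncnc(Nc3nc4ccc(C(=O)Nc5c(C)cccc5C)cc4s3)c2cc1OC`, compound 3 `COc1cc2c(Nc3nc4ccc(C(=O)Nc5c(C)cccc5C)cc4s3)ncnc2cc1OCCCN1CCCCC1` and the not yet measured compound 4 `COc1cc2c(Nc3nc4ccc(C(=O)Nc5c(C)cccc5C)cc4s3)ncnc2cc1OCCCN1CCCCC1C`. In a functional assay on HCT-116 cells (Homo sapiens) for cytotoxicity, read by WST assay, with a stated time of 72 h (a lower number here means a stronger inhibitor, a higher number a weaker inhibitor), compound 1 gives 7200 nM. For compound 2 the this assay reading is a limit of the assay, > 100000 nM. For compound 3 the this assay reading is likewise a limit, > 100000 nM. Compound 3 therefore stands at the limit of > 100000 nM in this assay, at which 2 of the 3 values shown sit, with no number of its own. Among the measured compounds shown here, the one measured step between neighbours, a step that the two limits leave unreadable from compound 2 to compound 3, is unreadable from the two limits. The change from compound 3 to compound 4 is methyl in place of hydrogen on a saturated ring carbon. For the measured compounds named here, no measured step maps onto this change; compound 1 carries the same 2-methylpiperidin-1-yl end but differs elsewhere as well, so its value shows only that a number can be reached with that end. A step of an at least 1.2-fold lower number from compound 3 to compound 4 (0.09 log units; that floor lies within the scatter) is expected, with a fair chance that compound 4 again returns only a limit. Compound 4 is expected at 80000 nM, between 15000 nM and 300000 nM.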

Compound 4, half-maximal inhibitory concentration: > 100000 nM
Compound 4: no number, only a limit; the forecaster's own chance of this, stated with the estimate: 55%; middle value at least 1.2-fold (0.09 log units) from the limit.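

In this assay, among the compounds shown here, methyl in place of chloro on an aromatic carbon of the anilide gives an at least 13-fold higher number from compound 1 to compound 4 (1.14 log units; beyond the scatter); with the 2-methylpiperidin-1-yl end held fixed, this is the first readable step, and it places the change on the anilide rather than on the amine end. Methyl on a saturated ring carbon, next to the ring nitrogen, does not bring compound 4 off the limit: the limit of > 100000 nM in this assay, at which 3 of the 4 values shown sit. The steps among compound 2, compound 3 and compound 4 cannot be read, as each joins two limits.

On these data alone, whether chloro on the anilide gives a number with the piperidin-1-yl or diethylamino end remains open, so the part played by the 2-methylpiperidin-1-yl end in compound 1 is unknown. As far as these compounds go, how bromo at that aromatic place, or a morpholin-4-yl end on the chain, would read is also open.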